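The source may hold more compounds than are shown below. What is called first, only, known or untested is meant among the compounds shown, and "the series" means these compounds.

Working notes on the series.

Of the compounds shown here, three have been tested in a functional assay on MDA-MB-231 cells (Homo sapiens) for inhibition, read by MTT assay, with a stated time of 72 h; a higher number here means a weaker inhibitor, a lower number a stronger inhibitor. Compound 1 `CNC(=O)CCCCCCCn1nc(-c2cnc3[nH]ccc3c2)c2c(N)ncnc21` gives 15800 nM. Compound 2 `Nc1ncnc2c1c(-c1cnc3[nH]ccc3c1)nn2CCCCCCC(=O)NO` gives 37700 nM. Compound 3 `CNC(=O)CCCCCCCn1nc(-c2ccc3oc(N)nc3c2)c2c(N)ncnc21` gives 2900 nM and stands lowest of the three.

Two single-point changes connect them. The side-chain change from compound 1 to compound 2 is hydroxycarbamoyl in place of (methylcarbamoyl)methyl on a saturated chain carbon, six bonds along the chain from an aromatic nitrogen and it reads a 2.4-fold higher number from compound 1 to compound 2 (0.38 log units; beyond the scatter). The core change from compound 1 to compound 3 is a group of 10 heavy atoms (7 carbon, 2 nitrogen, 1 oxygen; one five-membered aromatic ring with 2 hetero atoms, one six-membered aromatic ring of carbon only) in place of a group of 9 heavy atoms (7 carbon, 2 nitrogen; one five-membered aromatic ring with 1 hetero atom, one six-membered aromatic ring with 1 hetero atom), on an aromatic carbon and it reads a 5.4-fold lower number from compound 1 to compound 3 (0.74 log units; beyond the scatter). For the measured compounds named here, compound 2 and compound 3 differ in both places at once; no single step is counted between them, and their numbers simply stand apart by what the two values show.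

Compound 4 `Nc1nc2cc(-c3nn(CCCCCCC(=O)NO)c4ncnc(N)c34)ccc2o1` is not yet measured. It carries the core of compound 3 and the side chain of compound 2, so it closes the square. Its difference from compound 3 is hydroxycarbamoyl in place of (methylcarbamoyl)methyl on a saturated chain carbon, six bonds along the chain from an aromatic nitrogen. This is the same change as from compound 1 to compound 2, at the same place by the same description, and it occurs twice in all among the compounds shown.

Going by the values given here, for compound 4 in this assay the expected step is a 2.4-fold higher number from compound 3 to compound 4 (0.38 log units; beyond the scatter), resting on the single precedent of a 2.4-fold higher number from compound 1 to compound 2 (0.38 log units; beyond the scatter) on the other core. From the compounds shown here alone, whether the change carries over unchanged onto the core of compound 3 is untested, so the range is kept wide. Compound 4 is estimated at 7000 nM, between 3000 nM and 16000 nM.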

Compound 4, half-maximal inhibitory concentration: 8430 nM
The estimate for compound 4 lay 1.2-fold (0.08 log units) below the measured number; the range from low to high includes it.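

The side-chain change, carried onto the second core, reads in this assay as a 2.9-fold higher number from compound 3 to compound 4 (0.46 log units; beyond the scatter), and it agrees with its first reading on the other core: the same change on two cores in this assay, a 2.4-fold higher number (0.38 log units; beyond the scatter) from compound 1 to compound 2 and a 2.9-fold higher number (0.46 log units; beyond the scatter) from compound 3 to compound 4, 1.2-fold (0.09 log units) apart, within the scatter of two such steps. The core change, read with hydroxycarbamoyl at the chain end, is a 4.5-fold lower number from compound 2 to compound 4 (0.65 log units; beyond the scatter), and it also agrees with its first reading: the same change on two cores in this assay, a 5.4-fold lower number (0.74 log units; beyond the scatter) from compound 1 to compound 3 and a 4.5-fold lower number (0.65 log units; beyond the scatter) from compound 2 to compound 4, 1.2-fold (0.09 log units) apart, within the scatter of two such steps. Within this square of four compounds, each change therefore keeps its size whichever partner it sits with, but this rests on one pair of readings per change in one cell assay and shows neither why the numbers move nor that the same would hold on any other core.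

The compounds shown leave open whether the same carry-over holds for other groups at the chain end, such as a carboxylic acid or an amine in place of hydroxycarbamoyl, or for a shorter or longer chain. They also leave open how these two changes read in other cell lines, or with a different group in place of either of the two aromatic ring systems on the shared core.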